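Cytotoxicity of a difluoroanilide amide in the shared core

This account rests on a few compounds, and the source may have more. Where it says the series, first, only, none or still open, it means among the compounds named here.

Compound 1 `CC(C)n1ncc2c(C(=O)N3CCc4cccnc43)cc(-c3cccs3)nc21` carries an amide built on a fused bicyclic amine and is tested in an ADME assay on LLC-MK2 cells (Macaca mulatta) for cytotoxicity, read by spectrophotometry and crystal violet staining, with a stated time of 4 days (a higher number here means that more compound is tolerated, a lower number that less compound is tolerated), where compound 1 gives 50000 nM. Among the two plain numbers in hand this is the higher, but only just: compound 3 `CC(C)n1ncc2c(C(=O)Nc3ccccc3F)cc(-c3ccncc3)nc21`, which pairs a fluorophenylamino amide with a pyridyl group in place of the thienyl group, gives 45000 nM in this assay, and the gap to compound 1 lies within the scatter of repeated runs. Compound 2 `CC(C)n1ncc2c(C(=O)N3CCc4cc(F)ccc43)cc(-c3cccs3)nc21` reaches no number in this assay; its result of > 200000 nM is a limit, the assay's upper bound described by the limit of > 200000 nM in this assay, at which 1 of the 3 values shown sits.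

Compound 4 `CC(C)n1ncc2c(C(=O)Nc3cc(F)ccc3F)cc(-c3cccs3)nc21` has not yet been measured in this assay. It differs from compound 1 in a single place: a group of 9 heavy atoms (6 carbon, 1 nitrogen, 2 fluorine; one six-membered aromatic ring of carbon only) in place of a group of 9 heavy atoms (7 carbon, 2 nitrogen; one five-membered non-aromatic ring with 1 hetero atom, one six-membered aromatic ring with 1 hetero atom), on a carbonyl carbon.

Within the data shown here, no measured pair in this set isolates that change, so its size is open. Compound 3 shows that an anilide of this kind on the same core sits close to compound 1, so the step from compound 1 to compound 4 is expected to stay within the scatter, with no change at the digits printed from compound 1 to compound 4 (within the scatter). For compound 4 in this assay a value of 50000 nM is expected, with a likely range from 20000 nM to 150000 nM.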

Compound 4, half-maximal cytotoxic concentration: 100000 nM
The estimate for compound 4 lay 2.0-fold (0.30 log units) below the measured number; low and high end bracket the measured number.
By their numbers in this assay, from the lowest: compounds 3, 1 and 4 (each within the scatter of the next, the first and the last beyond it). At a limit, above all of these: compound 2.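

Setting (2,5-difluorophenyl)amino on the carbonyl carbon in place of the fused bicyclic amine of compound 1 gives a 2.0-fold higher number from compound 1 to compound 4 (0.30 log units; within the scatter) in this assay. Among these compounds, this is the first step in the set that reads a change at this position alone, as the earlier compounds offered no pair differing in one place, and it shows that here a group with a six-membered aromatic ring of carbon only and an amide hydrogen can replace one with no hydrogen-bond donor without moving the number beyond the scatter. Compound 2 remains the only compound at a limit, which is not a number: the limit of > 200000 nM in this assay, at which 1 of the 4 values shown sits.

What the compounds shown leave open is how the step divides among the ring, the two fluorines and the amide hydrogen, all of which change together here. A plain phenylamino group on the same carbonyl carbon would begin to separate the part played by the fluorines, and an open-chain amine such as dimethylamino would test whether any ring is needed there at all.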